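The source may report more compounds than this note shows. Statements on the series, on what has been measured and on what is new or still open speak of the compounds shown alone.

For the measured compounds named here, compound 2 `CCOC(=O)C1=CCCCC1S(=O)(=O)Cc1ccc(Cl)c(Cl)c1` gives 53 nM in a functional assay on RAW264.7 cells (Mus musculus), read by fluorescence (on this read-out lower numbers stand for stronger inhibition and higher numbers for weaker inhibition), and holds the higher of the two numbers measured so far; compound 1 `CCOC(=O)C1=CCCCC1S(=O)(=O)Cc1cccc(Cl)c1` gives 14 nM. Compound 3 `CCOC(=O)C1=CCCCC1S(=O)(=O)Cc1ccc(F)c(Cl)c1` differs from compound 2 by fluoro in place of chloro on an aromatic carbon. Going by the values given here, only one measured step bears on this spot: a 3.8-fold higher number from compound 1 to compound 2 (0.58 log units; beyond the scatter), where a chloro replaced hydrogen on the same aromatic carbon and the number rose. A fluoro, smaller than chloro, is expected to give a number between those of compound 1 and compound 2, so the expected step is a 1.8-fold lower number from compound 2 to compound 3 (0.25 log units; within the scatter). Compound 3 is therefore estimated at 30 nM, with a likely range from 12 nM to 80 nM.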

Compound 3, half-maximal inhibitory concentration: 13 nM
Estimate against measurement, compound 3: 2.3-fold (0.36 log units) above; measured number inside the range.
By their numbers in this assay, from the lowest: compounds 3 and 1 (each within the scatter of the next); then compound 2.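

Chloro and fluoro do not behave alike on this aromatic carbon: in this assay, the change to fluoro gives a 4.1-fold lower number from compound 2 to compound 3 (0.61 log units; beyond the scatter), so the rise seen with chloro does not extend to every halogen. Fluoro in place of hydrogen gives a 1.1-fold lower number from compound 1 to compound 3 (0.03 log units; within the scatter) and so leaves the number within the usual scatter. Nothing available here explains why the two halogens differ. From the compounds shown here alone, whether a methyl, a methoxy or an amine on this carbon would read like fluoro or like chloro remains open.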